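Moving the methyl group on compound 1

The compounds below may be only part of what the source reports. "The series", "measured", "known", "first", "only" and "open" are said of these compounds alone.

compound 1 `Cc1ccccc1-c1cc(-c2ccc(Cl)o2)cc(-c2ccsc2)n1` gives 4630 nM
compound 2 `Clc1ccc(-c2cc(-c3ccoc3)cc(-c3cccs3)n2)cc1` gives 50000 nM
compound 3 `Clc1ccc(-c2cc(-c3ccco3)cc(-c3cccs3)n2)cc1` gives > 100000 nM as a limit of the assay

All three were measured in a functional assay on HCT-15 cells (Homo sapiens) for cytotoxicity, in the presence of a further agent that is not named here (on this read-out lower numbers stand for stronger inhibition and higher numbers for weaker inhibition), and compound 1 holds the lowest number (4630 nM), while compound 2 sits higher (50000 nM), a gap beyond the usual scatter. For compound 3 the assay gives only a limit (> 100000 nM).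

Compound 4 `Cc1ccc(-c2cc(-c3ccc(Cl)o3)cc(-c3ccsc3)n2)cc1` has the same atoms as compound 1, joined differently (4-methylphenyl in place of 2-methylphenyl on an aromatic carbon), with 4-methylphenyl in place of 2-methylphenyl on an aromatic carbon. Going by the values given here, the only measured step (an at least 2.0-fold higher number from compound 2 to compound 3 (0.30 log units; that floor lies within the scatter)) exchanges furan-3-yl for furan-2-yl, and no measured step moves a methyl group, so it gives little guidance on size. Since compound 1 at 4630 nM has the lowest number shown, a modest rise in this assay is expected rather than a fall, though it may stay within the scatter. The expected change is only a rough estimate (a 1.9-fold higher number from compound 1 to compound 4 (0.29 log units; within the scatter)). Compound 4 is estimated at 9000 nM (expected range 2500 nM to 40000 nM).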

Compound 4, half-maximal inhibitory concentration: 7410 nM
For compound 4 the middle estimate is 1.2-fold (0.08 log units) above the measured one, and the stated range covers the measured number.
By their numbers in this assay, from the lowest: compounds 1 and 4 (each within the scatter of the next); then compound 2. At a limit, above all of these: compound 3.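

In this assay, moving the methyl group around the phenyl ring gives a 1.6-fold higher number from compound 1 to compound 4 (0.20 log units; within the scatter), so the 2-methylphenyl and 4-methylphenyl groups cannot be told apart at this position next to the ring nitrogen. This is the first step shown that changes the group at this position, as the earlier step concerned only the furan attachment. Within this pair, the position of the methyl group on the phenyl ring therefore has no effect that can be read beyond the scatter. Nothing among the data shown offers a cause for this result.

The compounds shown leave open how 3-methylphenyl would behave at this position. They also leave open whether an amine or a carboxylic acid in place of the methyl group would move the number beyond the scatter.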